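Benzyloxy in Place of Pyrrolidinyl: Expected Cytotoxicity of Compound 4

The source may hold more compounds than are shown below. What is called first, only, known or untested is meant among the compounds shown, and "the series" means these compounds.

Of the compounds shown here, three sharing one core have been tested in an ADME assay on HFF cells (Homo sapiens) for cytotoxicity, with a stated time of 8 days; a higher number here means that more compound is tolerated, a lower number that less compound is tolerated. Compound 1 `CCCNc1nc(N)nc2c1ncn2/C=C1/CC1(CO)CO` carries a propylamino group; compound 2 `CC(C)CNc1nc(N)nc2c1ncn2/C=C1/CC1(CO)CO` an isobutylamino group; compound 3 `Nc1nc(N2CCCC2)c2ncn(/C=C3/CC3(CO)CO)c2n1` a pyrrolidin-1-yl group. In this assay compound 1 reaches only the limit of > 300000 nM. Compound 2 likewise reaches only the limit of > 300000 nM. Compound 3 also reaches only the limit of > 300000 nM, so no number is known for it, and all three sit at the same limit, as the limit of > 300000 nM in this assay, at which 3 of the 3 values shown sit, records.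

The measured steps give little guidance: a step that the two limits leave unreadable from compound 1 to compound 2, a step that the two limits leave unreadable from compound 1 to compound 3 and a step that the two limits leave unreadable from compound 2 to compound 3 are all unreadable because both ends sit at a limit. Compound 4 `Nc1nc(OCc2ccccc2)c2ncn(/C=C3/CC3(CO)CO)c2n1` differs from compound 3 in that (benzyloxy in place of pyrrolidin-1-yl on an aromatic carbon). Within the data shown here, none of the measured steps describes this change, and none shows any compound falling below the limit. Compound 4 is therefore expected to tolerate a similar amount, with no step beyond the scatter, which would mean a number no higher from compound 3 to compound 4 (the limit leaves the size open). The estimate for compound 4 is 300000 nM, within a range from 100000 nM to 1000000 nM, most likely again reported as a limit.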

Compound 4, half-maximal cytotoxic concentration: > 300000 nM
Compound 4: only a limit was reported; the forecaster's own chance of this, stated with the estimate: 75%; the middle value lies on the limit itself.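

No step can be read between compound 4 and compounds 1, 2 or 3, because both ends of every comparison in this assay are limits rather than numbers: the limit of > 300000 nM in this assay, at which 4 of the 4 values shown sit.

The compounds shown leave open how much of each compound the cells tolerate, and whether changing the group on the shared core alters that amount.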